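Amide series on a shared core: cytotoxicity notes

This account rests on a few compounds, and the source may have more. Where it says the series, first, only, none or still open, it means among the compounds named here.

Compound 1 `Cc1ccccc1C(=O)Nc1nc(-c2ccccn2)cs1` gives 6300 nM in an ADME assay on Vero cells (Chlorocebus sabaeus) for cytotoxicity, read by MTT assay, with a stated time of 72 h; on this read-out lower numbers stand for an effect already at smaller amounts and higher numbers for an effect only at larger amounts of compound. Compound 2 `O=C(Nc1nc(-c2ccccn2)cs1)c1ccccc1O` carries a 2-hydroxyphenyl on the carbonyl carbon; in this assay compound 2 gives "not determined" (no result reported), so it cannot be placed against compound 1. Compound 3 `O=C(Nc1nc(-c2ccccn2)cs1)c1ccc(Br)cc1` differs from compound 2 by 4-bromophenyl in place of 2-hydroxyphenyl on a carbonyl carbon. For the measured compounds named here, with no measured step at hand, the change from compound 2 to compound 3 is expected to move the read-out in this assay by no more than the usual scatter, in no set direction. Compound 3 is estimated at 6000 nM in this assay, within 1500 nM to 25000 nM.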

Compound 3, half-maximal effective concentration: 4700 nM
Compound 3: the middle estimate sits 1.3-fold (0.11 log units) above what was measured; low and high end bracket the measured number.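

In this assay, for the compounds shown here, the first readable step at this position is a 1.3-fold lower number from compound 1 to compound 3 (0.13 log units; within the scatter), with 4-bromophenyl in place of 2-methylphenyl on a carbonyl carbon. Between these two compounds, the exchange of one substituted phenyl for the other therefore produces no change beyond the scatter. No available evidence bears on this result.

Compound 2 has no number, so steps involving it cannot be read, and the effect of its 2-hydroxyphenyl remains unplaced. Going by these compounds, whether an amine, a carboxylic acid or a longer chain on the carbonyl carbon would shift the read-out remains open.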